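Following the Side Chain from Compound 2 to Compound 3

The source may hold more compounds than are shown below. What is called first, only, known or untested is meant among the compounds shown, and "the series" means these compounds.

Measured in a functional assay on MCF7 cells (Homo sapiens) for cytotoxicity, read by MTT assay, with a stated time of 72 h; a higher number here means a weaker inhibitor, a lower number a stronger inhibitor:
- compound 1 `CC1(C)OCC(Cn2cc(Cn3c4c(c5ccccc53)C(=O)c3c[n+]([O-])c5ccccc5c3C4=O)nn2)O1`: 290 nM
- compound 2 `CCCN1CCN(CCCCn2c3c(c4ccccc42)C(=O)c2c[n+]([O-])c4ccccc4c2C3=O)CC1`: 1280 nM

Of the two measured compounds, compound 2 has the higher number, and thus the weaker inhibition, at 1280 nM. Its gap to compound 1 lies beyond the usual scatter. Compound 3 `O=C1c2c[n+]([O-])c3ccccc3c2C(=O)c2c1c1ccccc1n2Cc1cn(C[C@@H](O)CO)nn1` has not yet been measured. In it, 1-(2,3-dihydroxypropyl)-1H-1,2,3-triazol-4-yl stands in place of 3-(4-propylpiperazin-1-yl)propyl on a saturated chain carbon bound to an aromatic nitrogen (1-(2,3-dihydroxypropyl)-1H-1,2,3-triazol-4-yl in place of 3-(4-propylpiperazin-1-yl)propyl on a saturated chain carbon bound to an aromatic nitrogen). Compound 1, whose side chain also holds a triazole, gives 290 nM, so a moderate move to a lower number is expected, although two measured compounds offer thin support. The expected change is a 2.3-fold lower number from compound 2 to compound 3 (0.37 log units; beyond the scatter). Compound 3 is estimated at 550 nM, with an expected range of 170 nM to 1800 nM.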

Compound 3, half-maximal inhibitory concentration: 600 nM
Estimate against measurement, compound 3: 1.1-fold (0.04 log units) below; the measured number falls inside the stated range.
By their numbers in this assay, from the lowest: compound 1; then compound 3; then compound 2.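

In this assay, 1-(2,3-dihydroxypropyl)-1H-1,2,3-triazol-4-yl in place of 3-(4-propylpiperazin-1-yl)propyl gives a 2.1-fold lower number from compound 2 to compound 3 (0.33 log units; beyond the scatter) and so shows that this position accepts a change of the whole side chain with a modest shift. With the triazole kept, 1,2-dihydroxyethyl in place of 2,2-dimethyl-1,3-dioxolan-4-yl gives a 2.1-fold higher number from compound 1 to compound 3 (0.32 log units; beyond the scatter) and shows that the number still moves when only the group carried on the triazole changes. Nothing measured here accounts for either step.

The step from compound 2 cannot be divided between the triazole and the two hydroxyl groups, since both enter together. Also open, from the compounds shown here alone, is how a triazole carrying an amine or a carboxylic acid would read, and what the opposite configuration of the stereocentre in compound 3 would give.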